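The source may hold more compounds than are shown below. What is called first, only, known or untested is meant among the compounds shown, and "the series" means these compounds.

Measured so far:
Compound 1 `CN1C/C(=C\c2cccs2)C(O)/C(=C/c2cccs2)C1`: 81400 nM
Compound 2 `CN1C/C(=C\c2cccs2)C2=NN(C)C(c3cccs3)C2C1`: 74400 nM

Both compounds were tested in a functional assay on cells (Ovarian cancer cell line, Homo sapiens) for inhibition; on this read-out higher numbers stand for weaker inhibition of growth and lower numbers for stronger inhibition of growth. In this test, compound 2 gives 74400 nM, while compound 1 gives 81400 nM. These two numbers lie within the usual scatter of each other, so the data do not rank compound 2 against compound 1. Both stand as the only reference points for the next compound.

That compound is compound 3 `CN1C/C(=C\c2cccs2)C2=NN(c3ccccc3)C(c3cccs3)C2C1`, which has phenyl in place of methyl on an amine nitrogen in a ring, compared with compound 2: phenyl in place of methyl on an amine nitrogen in a ring. Among the measured compounds shown here, the measured pair offers no step that differs in one place, so nothing yet shows what this kind of change does in this assay. The expectation is therefore tentative: a moderate move toward stronger inhibition of growth, with a real chance of no change beyond the scatter. The expected step is a 1.9-fold lower number from compound 2 to compound 3 (0.27 log units; within the scatter), and this remains an estimate.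

Compound 3 is estimated at 40000 nM, with an expected range of 13000 nM to 100000 nM.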

Compound 3, concentration for 50% growth inhibition: 24200 nM
The estimate for compound 3 lay 1.7-fold (0.22 log units) above the measured number; the range from low to high includes it.
By their numbers in this assay, from the lowest: compound 3; then compounds 2 and 1 (each within the scatter of the next).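

Phenyl in place of methyl on the amine nitrogen of the five-membered non-aromatic ring gives, in this assay, a 3.1-fold lower number from compound 2 to compound 3 (0.49 log units; beyond the scatter) and this modest change is the only step here that can be read, which marks this nitrogen as a place where the group can shift the number beyond the scatter. The direction is toward stronger inhibition of growth, but the change brings in more carbon atoms and a six-membered aromatic ring together, and this single pair cannot separate those two differences. Nothing measured here explains why the step occurs.

Still open, on these data alone, is whether another group on this nitrogen, such as ethyl, benzyl or a pyridine ring, would give a similar, larger or smaller step, and whether a methoxy group or a chlorine atom on the phenyl ring would move the number further. Also open, as far as these compounds go, is whether furan-2-yl rings in place of the thiophen-2-yl groups would change inhibition of growth on this scaffold.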